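Swapping an indole for an indazole on a shared core

The compounds below may be only part of what the source reports. "The series", "measured", "known", "first", "only" and "open" are said of these compounds alone.

Of the compounds shown here, three built on one core have been measured. In a physicochemical assay for lipophilicity, at pH 7.4 (on this read-out higher numbers stand for higher lipophilicity and lower numbers for lower lipophilicity), compound 1 `CNC(=O)c1cc(C(N)=O)cn(Cc2ccccc2)c1=O` gives 2, and compound 3 `CNC(=O)c1cc(C(=O)NC)c(=O)n(Cc2ccccc2)c1` gives 2.4, which is a number 0.40 log units higher from compound 1 to compound 3 (beyond the scatter). Compound 2 `CNC(=O)c1cc(C(=O)NC2CC2)cn(Cc2cccc3cc[nH]c23)c1=O` gives 3.7, the highest of the three, with its steps to both others beyond the scatter. Compound 4 `CNC(=O)c1cc(C(=O)NC2CC2)cn(Cc2cccc3cn[nH]c23)c1=O` differs from compound 2 in one place: 1H-indazol-7-yl in place of 1H-indol-7-yl on a saturated chain carbon bound to an aromatic nitrogen. Among the measured compounds shown here, no measured step exchanges one ring system for another; the single measured step concerns a methyl on an amide-type nitrogen and offers no direct guide here. Compound 4 is therefore estimated at 3, within a range from 2.4 to 3.6. The expected step is a number 0.70 log units lower from compound 2 to compound 4 (beyond the scatter).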

Compound 4, distribution coefficient: 2.2
The estimate for compound 4 lay 0.80 log units above the measured number, outside the stated range (below it).
By their numbers in this assay, from the lowest: compounds 1, 4 and 3 (each within the scatter of the next, the first and the last beyond it); then compound 2.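

At this place, on a saturated chain carbon bound to an aromatic nitrogen, exchanging 1H-indol-7-yl for 1H-indazol-7-yl gives a number 1.50 log units lower from compound 2 to compound 4 (beyond the scatter) in this assay. The size of this step shows that the read-out is highly sensitive to this exchange, even though both groups have the same number of heavy atoms and the entering group adds a hydrogen-bond acceptor. Nothing available explains the size of the step. Still open, on these data alone, is how an amine or a carboxylic acid in this place would read in this assay, and whether the same exchange gives a step of similar size on a different core.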